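Moving the chlorine on the amide aryl ring: compound 4

The source may report more compounds than this note shows. Statements on the series, on what has been measured and on what is new or still open speak of the compounds shown alone.

Measured compounds:
Compound 1, `CNc1cc(C)c2cc(NC(=O)c3ccc(Cl)c(Cl)c3)ccc2n1`: in a functional assay on SK-BR-3 cells (Homo sapiens) for antiproliferative activity, read by MTT assay, with a stated time of 72 h (a higher number here means a weaker inhibitor, a lower number a stronger inhibitor), compound 1 gives 6350 nM.
Compound 2, `CCN1CCN(c2cc(C)c3cc(NC(=O)c4cccc(Cl)c4)ccc3n2)CC1`: in this assay compound 2 gives 17800 nM.
Compound 3, `Cc1cc(N2CCN(C)CC2)nc2ccc(NC(=O)c3ccc(Cl)c(Cl)c3)cc12`: in this assay compound 3 gives 6320 nM.

Among these three, compound 2 stands at the highest number in this assay, and its distance to compound 1 and to compound 3 is beyond the scatter in both cases. The unmeasured compound 4, `CCN1CCN(c2cc(C)c3cc(NC(=O)c4ccccc4Cl)ccc3n2)CC1`, differs from compound 2 in a single respect: 2-chlorophenyl in place of 3-chlorophenyl on a carbonyl carbon.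

Going by the values given here, only one step between measured compounds is available, a 1.0-fold lower number from compound 1 to compound 3 (0.00 log units; within the scatter), and it concerns the amine on the aromatic carbon of the core, not the chlorophenyl on the carbonyl carbon. Among the compounds with values here, no measured pair exchanges 3-chlorophenyl for 2-chlorophenyl, so nothing here speaks directly to the change from compound 2 to compound 4. Within the data shown here, with no directly relevant precedent, the expectation for compound 4 in this assay is a number close to that of compound 2, with no step beyond the scatter in either direction, and the estimate is written as a 1.0-fold higher number from compound 2 to compound 4 (0.00 log units; within the scatter).

Compound 4 is therefore estimated at 18000 nM in this assay, within a range from 6000 nM to 55000 nM.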

Compound 4, half-maximal inhibitory concentration: > 50000 nM
Compound 4 was reported as a limit (the forecaster's own chance of this, stated with the estimate: 10%); at least 2.7-fold (0.44 log units) between middle value and limit.
By their numbers in this assay, from the lowest: compounds 3 and 1 (each within the scatter of the next); then compound 2. At a limit, above all of these: compound 4.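

Moving the chlorine gives the first step in this series that concerns the group on the carbonyl carbon: in this assay, 2-chlorophenyl in place of 3-chlorophenyl gives an at least 2.8-fold higher number from compound 2 to compound 4 (0.44 log units; beyond the scatter). Going by these compounds alone, the only earlier step, which exchanged methylamino for 4-methylpiperazin-1-yl on an aromatic carbon of the core, was a 1.0-fold lower number from compound 1 to compound 3 (0.00 log units; within the scatter), so this is the first sign in these compounds that a change of the same atoms, joined differently, on the amide side can separate two compounds beyond the scatter. Compound 4 stands as a limit and not as a number, and the step gives only a lower bound on the change: the limit of > 50000 nM in this assay, at which 1 of the 4 values shown sits.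

The compounds shown leave open whether the step follows the place of the chlorine alone, which a methyl or a methoxy group on the same ring, or a plain phenyl with no chlorine, would help to tell. They also leave open whether 2-chlorophenyl on the carbonyl carbon would read the same way with methylamino on the core, as in compound 1, instead of the ethyl-bearing piperazine of compound 4.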